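Changing the aryl group: three measured compounds, one estimate

This account rests on a few compounds, and the source may have more. Where it says the series, first, only, none or still open, it means among the compounds named here.

Compound 1, `COc1cncc(-c2c(C)nn(-c3nc(-c4ccc(Cl)c(Cl)c4)c(SC(C)C)s3)c2C(=O)O)c1`, gives 21000 nM in a functional assay on BJAB cells (Homo sapiens) for antiproliferative activity, with a stated time of 4 days; on this read-out higher numbers stand for an effect only at larger amounts of compound and lower numbers for an effect already at smaller amounts.
Compound 2, `Cc1nn(-c2nc(-c3ccc(Cl)c(Cl)c3)c(SC(C)C)s2)c(C(=O)O)c1-c1cccc(C(F)(F)F)c1`, gives 22000 nM in this assay.
Compound 3, `Cc1nn(-c2nc(-c3ccc(Cl)c(Cl)c3)c(SC(C)C)s2)c(C(=O)O)c1-c1cccc(Cl)c1C`, gives 5100 nM in this assay.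

Compound 3 stands at the lowest number of the three, and both of its steps from the others are beyond the scatter: a 4.1-fold lower number from compound 1 to compound 3 (0.61 log units; beyond the scatter) and a 4.3-fold lower number from compound 2 to compound 3 (0.63 log units; beyond the scatter). Compounds 1 and 2 lie within the scatter of each other, a 1.0-fold higher number from compound 1 to compound 2 (0.02 log units; within the scatter).

Compound 4, `CNc1cc(-c2c(C)nn(-c3nc(-c4ccc(Cl)c(Cl)c4)c(SC(C)C)s3)c2C(=O)O)ccn1`, has not yet been measured in this assay. It differs from compound 3 in one place: 2-(methylamino)pyridin-4-yl in place of 3-chloro-2-methylphenyl on an aromatic carbon. Among the measured compounds shown here, the step that bears most on this is the one from compound 1 to compound 3, where a pyridinyl group was replaced by the 3-chloro-2-methylphenyl group and the number fell by a modest amount. Compound 4 reverses that direction, bringing in a pyridinyl group again, so a move back toward the numbers of compounds 1 and 2 is expected. The expected step for compound 4 is a 2.9-fold higher number from compound 3 to compound 4 (0.47 log units; beyond the scatter). Compound 4 is therefore estimated at 15000 nM, with a range from 5000 nM to 45000 nM.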

Compound 4, half-maximal effective concentration: 18000 nM
Beside the measured number, compound 4's estimate is 1.2-fold (0.08 log units) below it, and the stated range covers the measured number.
By their numbers in this assay, from the lowest: compound 3; then compounds 4, 1 and 2 (each within the scatter of the next).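

In this assay, replacing 3-chloro-2-methylphenyl with a group that carries a ring nitrogen and a methylamino group gives a 3.5-fold higher number from compound 3 to compound 4 (0.55 log units; beyond the scatter). The new number also lies within the scatter of both earlier compounds, with a 1.2-fold lower number from compound 1 to compound 4 (0.07 log units; within the scatter) and a 1.2-fold lower number from compound 2 to compound 4 (0.09 log units; within the scatter), so three different groups at this aromatic carbon cannot be told apart, and only the 3-chloro-2-methylphenyl group of compound 3 stands apart from them. Nothing measured here offers an explanation for this pattern.

The compounds shown leave open whether a 3-chlorophenyl or a 2-methylphenyl group would by itself give a number like that of compound 3. They also leave open whether a dimethylamino group in place of the methylamino group would shift the number of compound 4.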